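A methyl on the aromatic nitrogen of compound 1

The compounds below may be only part of what the source reports. "The series", "measured", "known", "first", "only" and "open" are said of these compounds alone.

Compound 1 `CC(=O)N1CCN(c2ccc(Nc3nccc(-c4c[nH]c5ccccc45)n3)cc2)CC1` gives 33 nM in the measured series
Compound 2 `CN1CCN(c2cccc(Nc3nccc(-c4cn(C)c5ncccc45)n3)c2)CC1` gives 24 nM in the measured series

Both values come from a functional assay on MV4-11 cells (Homo sapiens) for antiproliferative activity, read by resazurin assay, with a stated time of 72 h (a higher number here means a weaker inhibitor of growth, a lower number a stronger inhibitor of growth), and lie within the usual scatter of each other, so compound 1 cannot be ranked against compound 2. Within the data shown here, the two differ in more than one place, and no single-change step between measured compounds is available.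

Compound 3 `CC(=O)N1CCN(c2ccc(Nc3nccc(-c4cn(C)c5ccccc45)n3)cc2)CC1` changes compound 1 in one place, from 1H-indol-3-yl to 1-methyl-1H-indol-3-yl, with methyl in place of hydrogen on an aromatic nitrogen is the whole difference. Compound 2 also carries a methyl on an aromatic nitrogen and reaches 24 nM in that read-out, so a large loss seems unlikely. No shift beyond the scatter is expected in this assay in either direction. The estimated 1.1-fold lower number from compound 1 to compound 3 (0.04 log units; within the scatter) is expected to remain within the scatter. Compound 3 is expected at 30 nM, within an estimated range of 12 nM to 75 nM for this measurement.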

Compound 3, concentration for 50% growth inhibition: 252 nM
Compound 3: middle estimate off by 8.4-fold (0.92 log units), on the low side; measured number above the stated range.
By their numbers in this assay, from the lowest: compounds 2 and 1 (each within the scatter of the next); then compound 3.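

In this assay, among these compounds, the hydrogen on the aromatic nitrogen of the 1H-indol-3-yl group proves not to be a free place for substitution: the single change to 1-methyl-1H-indol-3-yl brings a 7.6-fold higher number from compound 1 to compound 3 (0.88 log units; beyond the scatter) and gives the first step that can be read. Compound 2 also carries a methyl on an aromatic nitrogen, but it differs from compound 1 in more than one place, so its value cannot show how this position behaves on the core of compound 1. Nothing at hand accounts for the loss.

Left open is whether the loss follows the missing hydrogen or the added methyl, and how an ethyl, or a longer chain ending in an amine, would fare on this nitrogen. Also open, on these data alone, is whether the same change would cost as much on the core of compound 2.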